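The source may hold more compounds than are shown below. What is called first, only, known or untested is meant among the compounds shown, and "the series" means these compounds.

Measured compounds:
- compound 1, `O=C(Nc1ccc2nc(NC(=O)C3CCCCC3)sc2c1)c1ccc(Br)cc1`: > 4 ug/mL
- compound 2, `Cn1nccc1C(=O)Nc1ccc2nc(NC(=O)C3CCCCC3)sc2c1`: 0.58 ug/mL

Of the two values shown in a functional assay on WI-38 VA13 cells (Homo sapiens) for cytotoxicity (a higher number here means that more compound is needed for the effect, a lower number that less compound is needed), the number for compound 2 is the only one that is an actual number. For compound 1 the value > 4 ug/mL is a limit of this assay, one of the two values shown, as noted in the limit of > 4 ug/mL in this assay, at which 1 of the 2 values shown sits. Within the data shown here, compound 2 therefore stands as the one compound with a measured number, and the only step between measured compounds is an at least 6.8-fold lower number from compound 1 to compound 2 (0.83 log units; beyond the scatter), which replaced a carbonyl-bound aryl group by a carbonyl-bound aromatic heterocycle.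

Compound 3, `C=CCOC(=O)Nc1ccc2nc(NC(=O)C3CCCCC3)sc2c1`, differs from compound 2 by allyloxy in place of 1-methyl-1H-pyrazol-5-yl on a carbonyl carbon. Among the measured compounds shown here, the one measured step concerns the same carbonyl position but exchanges two aromatic groups, whereas here an aromatic group gives way to an open chain bound through oxygen, so the step bears on the place of change rather than on its kind. Given that the only known change at this position moved the number by an at least 6.8-fold lower number from compound 1 to compound 2 (0.83 log units; beyond the scatter), a shift of similar size in the opposite direction is expected for compound 3, estimated as a 3.4-fold higher number from compound 2 to compound 3 (0.54 log units; beyond the scatter), with a real chance that this assay returns only a limit. Compound 3 is therefore expected to give 2 ug/mL in this assay, between 0.6 ug/mL and 4 ug/mL.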

Compound 3, half-maximal effective concentration: 0.58 ug/mL
The estimate for compound 3 lay 3.4-fold (0.54 log units) above the measured number; measured number outside the range, below it.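

In this assay, the place on a carbonyl carbon whose other neighbour is an amide-type nitrogen accepts the ring-free allyloxy as well as the aromatic 1-methyl-1H-pyrazol-5-yl, with no change at the digits printed from compound 2 to compound 3 (within the scatter). An aromatic ring on this carbonyl carbon is therefore not needed to reach the number of compound 2, and the 4-bromophenyl of compound 1 stands apart from both other groups, with an at least 6.8-fold lower number from compound 1 to compound 3 (0.83 log units; beyond the scatter). The true size of that step stays unknown because compound 1 is held at a limit rather than a number: the limit of > 4 ug/mL in this assay, at which 1 of the 3 values shown sits.

The compounds shown cannot tell whether the oxygen or the double bond of allyloxy matters for this number, a question that a saturated propoxy or a plain butyl group on the same carbonyl carbon would bear on. Going by these compounds, it also remains open whether the number of compound 2 and compound 3 would persist with an amine, a carboxylic acid or a longer chain at this place.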